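The compounds below may be only part of what the source reports. "The series", "measured", "known", "first", "only" and "open" are said of these compounds alone.

Measured in a functional assay on HEL cells (Homo sapiens) (a higher number here means that more compound is tolerated, a lower number that less compound is tolerated), so far:
- Compound 1 `CCCCc1cc2cn(COCCO)c(=O)nc2o1` gives > 200000 nM as a limit
- Compound 2 `CCCCCCCC#Cc1cc2cn(COCCO)c(=O)nc2o1` gives > 50000 nM as a limit
- Compound 3 `O=c1nc2occc2cn1COCCO` gives > 200000 nM as a limit

Compound 1 has no number of its own, only a limit. All three values are limits, with the limit of > 200000 nM in this assay, at which 2 of the 3 values shown sit, and the limit of > 50000 nM in this assay, at which 1 of the 3 values shown sits, as the two levels shown, so compound 1 cannot be ranked against the others.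

For the measured compounds named here, compound 4 `CCCCCCCCCCc1cc2cn(COCCO)c(=O)nc2o1` differs from compound 1 by hexyl in place of hydrogen on a saturated chain carbon, four bonds along the chain from an aromatic carbon as its single change. Going by the values given here, the one measured step on this chain is a step that the two limits leave unreadable from compound 1 to compound 3 and it gives no size to carry over.

The chain of compound 4 comes closest in length to that of compound 2. Compound 2 has the limit > 50000 nM in this assay and this limit is the main guide here.

The expected change is an at least 3.3-fold lower number from compound 1 to compound 4 (0.52 log units; beyond the scatter) toward less compound tolerated, and this size is only loosely estimated. For compound 4 the estimate is 60000 nM with an expected range from 15000 nM to 200000 nM and a report as a limit alone is quite likely.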

Compound 4, half-maximal cytotoxic concentration: > 200000 nM
Compound 4: only a limit was reported; the forecaster's own chance of this, stated with the estimate: 65%; middle value at least 3.3-fold (0.52 log units) from the limit.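

In this assay compound 4 gives > 200000 nM as a limit. Compound 1 also has only a limit, and no step can be read from compound 1 to compound 4. The compounds shown leave open what half-maximal cytotoxic concentration any of them has, and whether chain length changes it.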